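The source may hold more compounds than are shown below. What is called first, only, known or untested is meant among the compounds shown, and "the series" means these compounds.

Working notes on the series. Compound 1 `COc1cc(/C=C/C(=O)c2sc(Nc3ccc(Cl)cc3)nc2C)cc(OC)c1OC` and compound 2 `COc1cc(/C=C/C(=O)c2sc(Nc3ccc(F)c(Cl)c3)nc2C)cc(OC)c1OC` share one core and differ only in the aryl group on the nitrogen on an aromatic ring. In a functional assay on NCI-H460 cells (Homo sapiens) for cytotoxicity, read by MTT assay (on this read-out higher numbers stand for weaker inhibition and lower numbers for stronger inhibition), compound 1 gives 22000 nM, and compound 2 gives 6310 nM. Among the compounds with values here, compound 2 thus holds the lowest of the two numbers, and the only measured step, a 3.5-fold lower number from compound 1 to compound 2 (0.54 log units; beyond the scatter), is the sole reference point for the amine substituent. Compound 3 `COc1cc(/C=C/C(=O)c2sc(Nc3ccccc3C)nc2C)cc(OC)c1OC` carries 2-methylphenyl in place of 3-chloro-4-fluorophenyl on a nitrogen on an aromatic ring. Within the data shown here, this change removes both halogens and brings in a methyl-bearing ring, which no measured pair covers directly; the single step to hand shows only that altering the halogen pattern on this phenyl shifts the number by a modest amount. With the halogenated ring gone, the expected direction is back toward the number of compound 1, with wide uncertainty. Compound 3 is therefore expected at 16000 nM (range 5000 nM to 50000 nM), an estimated step of a 2.5-fold higher number from compound 2 to compound 3 (0.40 log units; beyond the scatter).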

Compound 3, half-maximal inhibitory concentration: 6320 nM
Compound 3: the middle estimate sits 2.5-fold (0.40 log units) above what was measured; the measured number falls inside the stated range.
By their numbers in this assay, from the lowest: compounds 2 and 3 (each within the scatter of the next); then compound 1.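

In this assay, replacing 3-chloro-4-fluorophenyl with 2-methylphenyl on the nitrogen gives a 1.0-fold higher number from compound 2 to compound 3 (0.00 log units; within the scatter), so among these compounds a ring carrying no halogen matches the dihalogenated ring. Replacing 4-chlorophenyl with the same 2-methylphenyl gives a 3.5-fold lower number from compound 1 to compound 3 (0.54 log units; beyond the scatter), which leaves compound 1 as the only one of the three set apart from the others, and shows that a change at this position need not keep a halogen to lower the number. Nothing available accounts for these results.

The compounds shown leave open how the unsubstituted phenyl or a 4-methylphenyl ring would read here, so the part played by the methyl group alone is unsettled. Also open, as far as these compounds go, is how a methoxy group, an amine or a carboxylic acid on this ring would read.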